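Filling the Empty Aromatic Position of Compound 3 with Propyl

A few compounds are considered here, and "the series" means these few. Any claim that something is new, unique, unknown or untested is made for them only; others in the source may bear on it.

Measured compounds:
- compound 1, `CCSc1nc(N)c2nc(O)n(Cc3ccccc3)c2n1`, gives 0.1 mg/kg
- compound 2, `CCCCCSc1nc(N)c2nc(O)n(Cc3ccccc3)c2n1`, gives 1 mg/kg
- compound 3, `Nc1ncnc2c1nc(O)n2Cc1ccccc1`, gives 30 mg/kg

All three were tested in a functional assay on the whole organism for activation, with Mus musculus as the target; on this read-out higher numbers stand for an effect only at larger amounts of compound and lower numbers for an effect already at smaller amounts. Compound 3 stands at the highest number of the three: compound 2 lies nearest to it, with a 30-fold higher number from compound 2 to compound 3 (1.48 log units; beyond the scatter) separating them, and compound 1 lies furthest, with a 300-fold higher number from compound 1 to compound 3 (2.48 log units; beyond the scatter). Compound 3 is therefore the compound that needs the largest amount before an effect appears.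

Compound 4, `CCCc1nc(N)c2nc(O)n(Cc3ccccc3)c2n1`, differs from compound 3 in one place: propyl in place of hydrogen on an aromatic carbon. The two measured steps that bear on this change both run the other way, from a sulfur-linked chain at this same aromatic carbon to a bare hydrogen, and both raised the number strongly, by a 300-fold higher number from compound 1 to compound 3 (2.48 log units; beyond the scatter) and by a 30-fold higher number from compound 2 to compound 3 (1.48 log units; beyond the scatter). Placing a chain back on this carbon is expected to reverse that, lowering the number beyond the scatter. Among the measured compounds shown here, the new chain carries no sulfur, and no measured step shows such a chain at this carbon. The size of the reversal is uncertain, and the estimate for compound 4 is set between the two sulfur-chain compounds, as a step of a 15-fold lower number from compound 3 to compound 4 (1.18 log units; beyond the scatter). Compound 4 is thus expected to give about 2 mg/kg, with a range from 0.3 mg/kg to 10 mg/kg.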

Compound 4, minimum effective dose: 3 mg/kg
For compound 4 the middle estimate is 1.5-fold (0.18 log units) below the measured one; measured number inside the range.
By their numbers in this assay, from the lowest: compound 1; then compound 2; then compound 4; then compound 3.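

In this assay, a plain carbon chain on this aromatic carbon is enough to lower the number (a 10-fold lower number from compound 3 to compound 4 (1.00 log units; beyond the scatter)), so filling the position pays off even when no sulfur links the chain to the core. The sulfur-linked chains still do better, since replacing either of them with propyl raises the number, modestly for pentylsulfanyl (a 3.0-fold higher number from compound 2 to compound 4 (0.48 log units; beyond the scatter)) and by a large amount for ethylsulfanyl (a 30-fold higher number from compound 1 to compound 4 (1.48 log units; beyond the scatter)). Compound 4 therefore sits between compound 3 and the two sulfur-linked compounds, which shows that the chain on this carbon accounts for part of the drop in dose and that the choice of chain still matters a great deal.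

No supporting measurement is available to explain why the sulfur-linked chains give the lower numbers. As far as these compounds go, it also remains open how much of the gap belongs to the sulfur itself and how much to the chain's length, a question that an ethoxy group, joined through oxygen, or a plain pentyl chain at this same carbon would help to answer.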